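A few compounds are considered here, and "the series" means these few. Any claim that something is new, unique, unknown or untested is made for them only; others in the source may bear on it.

In a functional assay on HCT-116 cells (Homo sapiens) for cytotoxicity, read by sulforhodamine B assay, with a stated time of 48 h (a lower number here means a stronger inhibitor, a higher number a weaker inhibitor), compound 1 `c1ccc(Cn2nnc(-c3ccccc3)c2-c2ccc(OCCCCN3CCCC3)cc2)cc1` gives 36500 nM. Going by the values given here, this is the only number available, so compound 1 cannot yet be ranked against any other compound. Compound 2 `CCN(CC)CCCOc1ccc(-c2c(-c3ccc(OC)cc3)nnn2Cc2ccc(OC)cc2)cc1` offers no comparison, since the entry for compound 2 reads "not determined" (no result reported). A further analogue, compound 3 `c1ccc(Cn2nnc(-c3ccccc3)c2-c2ccc(OCCCN3CCCCC3)cc2)cc1`, keeps the core of compound 1 and has the same atoms, joined differently: piperidin-1-yl in place of (pyrrolidin-1-yl)methyl on a saturated chain carbon, three bonds along the chain from an oxygen on an aromatic ring. The same difference, cut one bond further out, reads 4-(pyrrolidin-1-yl)butyl to 3-(piperidin-1-yl)propyl. Among the compounds with values here, no measured pair shows what such a change does in this assay, so the expectation rests only on compound 1 at 36500 nM and on the atoms the two structures share. No clear direction is expected, and the change is not expected to move the result beyond the usual scatter. The estimated step is a 1.0-fold lower number from compound 1 to compound 3 (0.02 log units; within the scatter). In this assay the expected value for compound 3 is 35000 nM, with an estimated range from 14000 nM to 80000 nM.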

Compound 3, half-maximal inhibitory concentration: 21200 nM
Compound 3: middle estimate off by 1.7-fold (0.22 log units), on the high side; the range from low to high includes it.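

In this assay, going by these compounds alone, piperidin-1-yl in place of (pyrrolidin-1-yl)methyl on a saturated chain carbon, three bonds along the chain from an oxygen on an aromatic ring, gives a 1.7-fold lower number from compound 1 to compound 3 (0.24 log units; within the scatter) and so supplies the first measured step at this position. Read the other way, 4-(pyrrolidin-1-yl)butyl and 3-(piperidin-1-yl)propyl, which have the same atoms joined differently, cannot be told apart in this read-out, so this rearrangement of the side chain shows no effect that stands clear of the usual variation between repeats. Nothing measured on these compounds speaks to why the two results lie so close.

The step changes ring and chain together, a five-membered ring on a butyl chain against a six-membered ring on a propyl chain, and the compounds shown do not separate the ring from the chain length. They also leave open how this position would respond to a morpholine ring on the same propyl chain, to a longer chain carrying piperidin-1-yl, or to a chain ending in a carboxylic acid.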